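Two core variants carrying the same 4-methoxybenzyl change

The source may hold more compounds than are shown below. What is called first, only, known or untested is meant among the compounds shown, and "the series" means these compounds.

Measured so far:
Compound 1 `Cn1nc(-c2ccccc2)c2cc(C(=N)Nc3ccccc3)ncc21`: 17300 nM
Compound 2 `COc1ccc(Cn2nc(-c3ccccc3)c3cc(C(=N)Nc4ccccc4)ncc32)cc1`: 6300 nM
Compound 3 `Cn1cc2cc(C(=N)Nc3ccccc3)ncc2n1`: "not determined" (no result reported)

In a functional assay on PC-3 cells (Homo sapiens) for cytotoxicity, read by MTT assay, with a stated time of 72 h (a higher number here means a weaker inhibitor, a lower number a stronger inhibitor), compound 1 gives 17300 nM and compound 2 gives 6300 nM. The change between them is 4-methoxyphenyl in place of hydrogen on a saturated chain carbon bound to an aromatic nitrogen, and it made a step of a 2.7-fold lower number from compound 1 to compound 2 (0.44 log units; beyond the scatter). Compound 3, whose core differs from that of compound 1 in a way not broken down here, has no number in this assay: for compound 3 the result reads "not determined" (no result reported). Compound 4 `COc1ccc(Cn2cc3cc(C(=N)Nc4ccccc4)ncc3n2)cc1` arises from compound 3 by the same kind of change, (4-methoxyphenyl in place of hydrogen on a saturated chain carbon bound to an aromatic nitrogen), at the same place. He expects a step of similar modest size as the one seen between compound 1 and compound 2, but with no anchor for compound 3 the absolute level is uncertain. For compound 4 in this assay he estimates 15000 nM, between 4000 nM and 60000 nM.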

Compound 4, half-maximal inhibitory concentration: 2040 nM
Beside the measured number, compound 4's estimate is 7.4-fold (0.87 log units) above it; measured number below the stated range.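

Within the data shown here, compound 3 has no number to set against compound 4, so no step between them can be read. From the compounds shown here alone, whether the change from methyl to 4-methoxybenzyl does the same on both cores stays open. No evidence at hand bears on this result.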